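This account rests on a few compounds, and the source may have more. Where it says the series, first, only, none or still open, it means among the compounds named here.

Compound 1 `C=CCc1ccc(OCc2cn(-c3cccc([N+](=O)[O-])c3)nn2)c(O)c1`: 42.3%
Compound 2 `C=CCc1cc(O)c(O)c(CN2CCC(C)CC2)c1`: 41.7%
Compound 3 `C=CCc1ccc(OCc2cn(-c3ccc(C#N)cc3)nn2)c(O)c1`: 35.7%

All three values come from a functional assay on MCF7 cells (Homo sapiens) for inhibition, read by MTT assay, with a stated time of 72 h, tested at 30 uM; a lower number here means less inhibition of growth, a higher number more inhibition of growth at the concentration tested. Compound 3, at 35.7%, lies within the usual scatter of both compound 1 and compound 2, so the numbers do not set it apart from either one. The three compounds give a narrow picture, with no clear separation among them.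

The next compound to be tested is compound 4 `C=CCc1ccc(OCc2cn(-c3ccccc3Cl)nn2)c(O)c1`. It carries 2-chlorophenyl in place of the 4-cyanophenyl of compound 3, on an aromatic nitrogen of a five-membered aromatic ring with 3 nitrogen (2-chlorophenyl in place of 4-cyanophenyl on an aromatic nitrogen). The rest of the structure stays the same.

For the measured compounds named here, no two measured compounds differ in one place alone, so the data offer no direct guide to the size of this step in this assay. The nearest indication is compound 1, whose 42.3% stays within the scatter of the value of compound 3. On that basis, no change beyond the scatter is expected, and no direction is favoured. The expected step is a number 2.3 percentage points higher from compound 3 to compound 4 (within the scatter). The estimated value for compound 4 is 38%, with an expected range from 25% to 52%.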

Compound 4, percent growth inhibition at one concentration: 58.3%
Beside the measured number, compound 4's estimate is 20.3 percentage points below it; the measured number lies above the stated range.
By their numbers in this assay, from the lowest: compounds 3, 2 and 1 (each within the scatter of the next); then compound 4.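

In this assay, the replacement of 4-cyanophenyl by 2-chlorophenyl on the aromatic nitrogen of the ring with three nitrogens gives a number 22.6 percentage points higher from compound 3 to compound 4 (beyond the scatter), the first difference in this set that stands beyond the scatter. The earlier compounds shown here all lay within the scatter of one another and gave no sign that anything in their structures mattered, whereas this step shows that the group on this nitrogen can change growth inhibition at the concentration tested, with the rest of the structure held the same. Nothing in the data shown bears on why the step occurs.

The step swaps the substituent on the phenyl ring and also its place on that ring, so a single pair cannot show which of the two changes accounts for the difference. Also open, going by these compounds, is how an unsubstituted phenyl would compare, or a phenyl carrying a bromine or a methoxy group in place of the chlorine, and whether the higher number of compound 4 would hold across such neighbours.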